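A trimethoxyphenyl group replaces the phenylethenyl arm

The source may report more compounds than this note shows. Statements on the series, on what has been measured and on what is new or still open speak of the compounds shown alone.

Among the measured compounds shown here, compound 2 `Cc1cc(O)c(C2=NN(c3ccc(S(N)(=O)=O)cc3)C(/C=C/c3ccccc3)C2)cc1Cl` gives 4560 nM in a functional assay on MDA-MB-231 cells (Homo sapiens) for antiproliferative activity, with a stated time of 48 h (a lower number here means a stronger inhibitor of growth, a higher number a weaker inhibitor of growth), one of only two numbers recorded; the other belongs to compound 1 `Cc1cc(O)c(C2=NN(c3ccc(S(N)(=O)=O)cc3)C(c3ccccc3O)C2)cc1Cl`, which gives 2300 nM, the pair differing only within the scatter, as a 2.0-fold higher number from compound 1 to compound 2 (0.30 log units; within the scatter) shows. Compound 3 `COc1ccc(C2CC(c3cc(Cl)c(C)cc3O)=NN2c2ccc(S(N)(=O)=O)cc2)c(OC)c1OC` differs from compound 2 at a single saturated ring carbon: 2,3,4-trimethoxyphenyl in place of 2-phenylethenyl on a saturated ring carbon. For the measured compounds named here, the only step bearing on this position exchanged one arm for another there and stayed within the scatter, so no change beyond it is expected. The expected step is a 1.4-fold lower number from compound 2 to compound 3 (0.15 log units; within the scatter). Compound 3 is therefore estimated at 3200 nM, within 1200 nM to 8500 nM.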

Compound 3, concentration for 50% growth inhibition: 2090 nM
Compound 3: middle estimate off by 1.5-fold (0.19 log units), on the high side; the measured number falls inside the stated range.
By their numbers in this assay, from the lowest: compounds 3, 1 and 2 (each within the scatter of the next, the first and the last beyond it).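

Among the compounds shown here, at this saturated ring carbon, the 2,3,4-trimethoxyphenyl arm gives the first step beyond the scatter in this assay (a 2.2-fold lower number from compound 2 to compound 3 (0.34 log units; beyond the scatter)), so swapping the arm can shift the number, if only slightly. Against the 2-hydroxyphenyl arm, the same group makes no real difference (a 1.1-fold lower number from compound 1 to compound 3 (0.04 log units; within the scatter)), and compound 1 itself stays within the scatter of compound 2, so the three arms do not separate cleanly. Nothing available here explains these numbers.
Going by these compounds, what an amine or a carboxylic acid on this carbon would do remains open, as does the effect of a longer chain.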